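Glucagon receptor antagonists: pyrazole substituent change in a benzamide series

A few compounds are considered here, and "the series" means these few. Any claim that something is new, unique, unknown or untested is made for them only; others in the source may bear on it.

Measured so far:
- compound 1, `O=C(O)CCNC(=O)c1ccc(C(Oc2ccc(-n3cc(C(F)(F)F)cn3)cc2)C2CCCC2)cc1`: 4000 nM
- compound 2, `CCCC(Oc1ccc(-n2cc(C(=O)N(C)C)cn2)cc1)c1ccc(C(=O)NCCC(=O)O)cc1`: > 30000 nM
- compound 3, `CCCC(Nc1cnc(-n2cc(C(F)(F)F)cn2)nc1)c1ccc(C(=O)NCCC(=O)O)cc1`: 490 nM

In a functional assay on cells for antagonist activity at Glucagon receptor (Homo sapiens), read by cAMP accumulation, in the presence of a further agent that is not named here (on this read-out lower numbers stand for stronger inhibition and higher numbers for weaker inhibition), compound 2 gives only a limit, > 30000 nM, which is the assay limit of > 30000 nM in this assay, at which 1 of the 3 values shown sits, and not a number. Compound 1 in this assay gives 4000 nM and compound 3 gives 490 nM; both carry trifluoromethyl on the five-membered ring where compound 2 carries dimethylcarbamoyl.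

Compound 4, `CCCC(Oc1ccc(-n2cc(C)cn2)cc1)c1ccc(C(=O)NCCC(=O)O)cc1`, differs from compound 2 by methyl in place of dimethylcarbamoyl on an aromatic carbon. Methyl sits nearer to the trifluoromethyl of compound 1 and compound 3 than to the dimethylcarbamoyl of compound 2, so a step toward stronger inhibition is expected, an at least 3.7-fold lower number from compound 2 to compound 4 (0.57 log units; beyond the scatter), beyond the scatter. Compound 4 is estimated at 8000 nM in this assay, within 2500 nM to 30000 nM.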

Compound 4, antagonist equilibrium constant: 11000 nM
Compound 4: middle estimate off by 1.4-fold (0.14 log units), on the low side; measured number inside the range.
By their numbers in this assay, from the lowest: compound 3; then compound 1; then compound 4. At a limit, above all of these: compound 2.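

Swapping dimethylcarbamoyl for methyl on this aromatic carbon gives an at least 2.7-fold lower number from compound 2 to compound 4 (0.43 log units; beyond the scatter) in this assay, the first direct reading of this position, since no earlier pair differed in one place. The group on this carbon therefore matters, and a group far smaller than dimethylcarbamoyl is tolerated. The true size of the step stays unknown, and compound 2 gives only a limit: the limit of > 30000 nM in this assay, at which 1 of the 4 values shown sits.

On these data alone, compound 1 and compound 3 differ from compound 4 in more than one place, so how trifluoromethyl ranks against methyl on one core stays open. As far as these compounds go, how a nitrile or an ethyl group at this carbon would read also stays open.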